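The compounds below may be only part of what the source reports. "The series", "measured", "known", "first", "only" and "open" are said of these compounds alone.

Of the compounds shown here, three sharing one core have been measured in an ADME assay on SH-SY5Y cells (Homo sapiens) for cytotoxicity, read by MTT assay, with a stated time of 72 h; a lower number here means a stronger inhibitor, a higher number a weaker inhibitor. Compound 1 (`O=C(CN1CCN(C(=O)c2ccc(Br)cc2)CC1)N1CCN(CCCc2c[nH]c3ccc(F)cc23)CC1`) gives 47400 nM, compound 2 (`COc1cccc(C(=O)N2CCN(CC(=O)N3CCN(CCCc4c[nH]c5ccc(F)cc45)CC3)CC2)c1`) gives 79400 nM, and compound 3 (`O=C(CN1CCN(C(=O)c2cccc(F)c2)CC1)N1CCN(CCCc2c[nH]c3ccc(F)cc23)CC1`) gives 169000 nM. The measured steps around the middle value are a 1.7-fold higher number from compound 1 to compound 2 (0.22 log units; within the scatter) and a 2.1-fold higher number from compound 2 to compound 3 (0.33 log units; beyond the scatter). Compound 2 therefore cannot be told apart from compound 1, while compound 3 stands modestly clear of it.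

Compound 4 (`COc1cccc(C(=O)N2CCN(CC(=O)N3CCN(CCCc4c[nH]c5ccc(OC)cc45)CC3)CC2)c1`) departs from compound 2 in a single place, where 5-fluoro-1H-indol-3-yl becomes 5-methoxy-1H-indol-3-yl. This is methoxy in place of fluoro on an aromatic carbon.

For the measured compounds named here, the one measured step involving the same two groups is a 2.1-fold higher number from compound 2 to compound 3 (0.33 log units; beyond the scatter). It runs the opposite way, fluoro in place of methoxy, and lies at a different place in the molecule. Read in reverse, it points weakly to a lower number, but no measured compound tests the change at this position. The neighbouring step a 3.6-fold higher number from compound 1 to compound 3 (0.55 log units; beyond the scatter) shows only that modest shifts occur within this set.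

A small move is therefore expected, with the estimated change being a 1.3-fold lower number from compound 2 to compound 4 (0.11 log units; within the scatter), probably within the scatter. Compound 4 is expected at 62000 nM, with an estimated range from 25000 nM to 140000 nM.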

Compound 4, half-maximal inhibitory concentration: > 200000 nM
Compound 4 was reported as a limit; the forecaster's own chance of this, stated with the estimate: 10%; middle value at least 3.2-fold (0.50 log units) from the limit.
By their numbers in this assay, from the lowest: compounds 1 and 2 (each within the scatter of the next); then compound 3. At a limit, above all of these: compound 4.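

Methoxy in place of fluoro at this position, where 5-fluoro-1H-indol-3-yl becomes 5-methoxy-1H-indol-3-yl, gives an at least 2.5-fold higher number from compound 2 to compound 4 (0.40 log units; beyond the scatter) in this assay, so this end of the molecule can move the number beyond the scatter, which the earlier compounds could not show because all of them carry the same 5-fluoro-1H-indol-3-yl group. The result for compound 4 is a limit of the assay and not a number: the limit of > 200000 nM in this assay, at which 1 of the 4 values shown sits. The same pair of groups at the other end gives a 2.1-fold higher number from compound 2 to compound 3 (0.33 log units; beyond the scatter), with fluoro entering there and methoxy entering here, yet both steps go to a higher number, so the exchange read at one place does not carry over to the other in these compounds.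

The compounds shown leave open how far compound 4 lies past its limit, and whether methoxy at this place acts the same way when 4-bromophenyl or 3-fluorophenyl sits on the carbonyl carbon. They also leave open what a chloro group, a hydroxy group or a plain hydrogen would give at this position.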